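Extending the allyl on the ring nitrogen to a prenyl group

The source may report more compounds than this note shows. Statements on the series, on what has been measured and on what is new or still open speak of the compounds shown alone.

Compound 2: `C=CCN1CCC2CC(C1)c1ccccc12` with 19.4 mg/kg
Compound 1: `c1ccc2c(c1)C1CCNCC2C1` with 4.9 mg/kg

Compound 2 is the parent of the new change. In a functional assay on the whole organism with Mus musculus as the target, in the hot plate test (a higher number here means that more compound is needed for the effect, a lower number that less compound is needed), compound 2 gives 19.4 mg/kg, the highest of the two numbers recorded so far; its nearest neighbour is compound 1, which gives 4.9 mg/kg in this assay. Compound 3, `CC(C)=CCN1CCC2CC(C1)c1ccccc12`, differs from compound 2 in one place: 2-methylprop-1-en-1-yl in place of vinyl on a saturated chain carbon bound to an amine nitrogen in a ring. Going by the values given here, the only measured step that bears on this is a 4.0-fold higher number from compound 1 to compound 2 (0.60 log units; beyond the scatter), where an allyl group replaced hydrogen on the ring nitrogen. Making that chain larger still is not the same kind of change, and no measured pair shows its effect; the modest rise from compound 1 to compound 2 gives no clear direction for a further extension. For compound 3 the expected step is therefore a 1.4-fold lower number from compound 2 to compound 3 (0.14 log units; within the scatter), within the scatter. Compound 3 is estimated at 14 mg/kg, with a range from 4 mg/kg to 45 mg/kg.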

Compound 3, dose for half-maximal effect: "not active" (no number reported)
Nothing numeric was reported for compound 3; no gap can be computed for the estimate.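

Going by these compounds alone, compound 3 is reported only as "not active", without a number, so no step from compound 2 to compound 3 can be read. The compounds shown leave open how a 3-methylbut-2-en-1-yl chain compares numerically with allyl. No supporting measurement bears on this result.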